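A Methyl Replaces Nitro on the Aromatic Ring

This account rests on a few compounds, and the source may have more. Where it says the series, first, only, none or still open, it means among the compounds named here.

Of the compounds shown here, two sharing one core have been measured. Compound 1 `O=C1CSC(c2cccc(Cl)c2)N1CCN1CCCCC1` gives in an ADME assay on Vero cells (Chlorocebus sabaeus) for cytotoxicity, read by neutral red uptake, tested at 3150 ug/mL (on this read-out higher numbers stand for a weaker effect at the one concentration tested and lower numbers for a stronger effect), a value of 15%. Compound 2 `O=C1CSC(c2ccc([N+](=O)[O-])cc2)N1CCN1CCCCC1` gives in this assay a value of 10%. Compound 2 thus stands at the lower of the two numbers, and its nearest neighbour is compound 1, whose number lies a few points higher and within the scatter, so no order between the two can be read from these measurements. Compound 3 `Cc1ccc(C2SCC(=O)N2CCN2CCCCC2)cc1` has not yet been measured in this assay. It differs from compound 2 in one place: methyl in place of nitro on an aromatic carbon. Among the compounds with values here, no step between measured compounds is available to guide this change. Because compound 2 gives 10% and compound 1 gives 15%, numbers that lie within the scatter of each other, the expected step is a number 5 percentage points higher from compound 2 to compound 3 (within the scatter), that is, no change beyond the scatter. Compound 3 is therefore estimated to give in this assay a value of 15%, with a range from 5% to 30%.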

Compound 3, a percentage reported as activity, at one concentration (the size of the read-out at that concentration, not a potency): 12%
Compound 3: middle estimate off by 3 percentage points, on the high side, and the stated range covers the measured number.
By their numbers in this assay, from the lowest: compounds 2, 3 and 1 (each within the scatter of the next).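

In this assay the swap at this aromatic carbon, para to a large group, gives a number 2 percentage points higher from compound 2 to compound 3 (within the scatter) with methyl in place of nitro, so the first pair differing in this one place shows no change beyond the scatter. The read-out therefore does not separate these two groups here, although they differ in size and in hydrogen-bond acceptors as counted. The exchange of 3-chlorophenyl for 4-methylphenyl on the saturated ring carbon gives a number 3 percentage points lower from compound 1 to compound 3 (within the scatter) and likewise shows no separation, and no measurement available offers an explanation for either result.

As far as these compounds go, whether an amine or a carboxylic acid on this aromatic carbon would stay equally close to these numbers remains open. With a single concentration behind every value, the compounds shown also leave their relative potency undefined.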